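The source may report more compounds than this note shows. Statements on the series, on what has been measured and on what is new or still open speak of the compounds shown alone.

Compounds measured in an assay on cells for displacement of a labelled ligand from corticotropin-releasing factor receptor 1 (Homo sapiens), with a stated time of 100 min; on this read-out higher numbers stand for weaker inhibition and lower numbers for stronger inhibition: compound 1 `CCN(Cc1c(C(F)(F)F)nc2n(-c3c(C)cc(C)cc3C)c(Cl)cn12)CC1CCC1` gives 16 nM; compound 2 `CCN(CCC1CC1)Cc1c(C(F)(F)F)nc2n(-c3c(C)cc(C)cc3C)c(Cl)cn12` gives 13 nM.

Among the measured compounds shown here, compound 2 and compound 1 lie within the scatter of each other, the only measured step between them being a 1.2-fold lower number from compound 1 to compound 2 (0.09 log units; within the scatter). Compound 3 `Cc1cc(C)c(-n2c(Cl)cn3c(CN4CCCC(C)C4)c(C(F)(F)F)nc23)c(C)c1` has not been measured; it differs from compound 2 in one place: 3-methylpiperidin-1-yl in place of (2-cyclopropylethyl)(ethyl)amino on a saturated chain carbon bound to an aromatic carbon. For the measured compounds named here, the single measured step touched another part of the amine substituent and stayed within the scatter, so it offers little guidance here. For compound 3 a step of a 1.9-fold higher number from compound 2 to compound 3 (0.28 log units; within the scatter) is expected. The estimate for compound 3 is 25 nM, with a range from 8 nM to 80 nM.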

Compound 3, inhibition constant: 5800 nM
The estimate for compound 3 lay 230-fold (2.37 log units) below the measured number, outside the stated range (above it).
By their numbers in this assay, from the lowest: compounds 2 and 1 (each within the scatter of the next); then compound 3.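

At this amine, on a saturated chain carbon bound to an aromatic carbon, the change to 3-methylpiperidin-1-yl matters far more than the earlier change at the end of the open chain: in this assay it gives a 450-fold higher number from compound 2 to compound 3 (2.65 log units; beyond the scatter) and a 360-fold higher number from compound 1 to compound 3 (2.56 log units; beyond the scatter). The earlier compounds shown here showed only a step within the scatter, so this sensitivity is new. Nothing at hand explains the loss. From the compounds shown here alone, whether it belongs to the ring itself or to its methyl stays open; piperidin-1-yl without the methyl would separate the two.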